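The source may hold more compounds than are shown below. What is called first, only, known or untested is meant among the compounds shown, and "the series" means these compounds.

In an ADME assay on the whole organism (plasma) for pharmacokinetics, with Rhesus monkey (Macaca mulatta) as the target, with a stated time of 24 h, at a dose of 3 mg/kg by the oral route (on this read-out higher numbers stand for higher exposure at the dose given and lower numbers for lower exposure), compound 1 `C=CCNC(=O)C(=O)[C@H](CCCC)NC(=O)[C@@H]1[C@H]2[C@@H](CN1C(=O)[C@@H](NC(=O)NC1([C@H]3CCCS3(=O)=O)CCCCC1)C(C)(C)C)C2(C)C` gives 1520 ng.h/mL, compound 2 `CCCC[C@H](NC(=O)[C@@H]1[C@H]2[C@@H](CN1C(=O)[C@@H](NC(=O)NC1([C@H]3CCCS3(=O)=O)CCCCC1)C1(C)CCCCC1)C2(C)C)C(=O)C(=O)NC1CC1` gives 6590 ng.h/mL, and compound 3 `CCC[C@H](NC(=O)[C@@H]1[C@H]2[C@@H](CN1C(=O)[C@@H](NC(=O)NC1([C@H]3CCCS3(=O)=O)CCCCC1)C1(C)CCCCC1)C2(C)C)C(=O)C(=O)NC1CC1` gives 14900 ng.h/mL. Compound 3 thus holds the highest of the three numbers, and its gap to each of the other two lies beyond the usual scatter.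

The next compound, compound 4 `CC1([C@H](NC(=O)NC2([C@H]3CCCS3(=O)=O)CCCCC2)C(=O)N2C[C@@H]3[C@H]([C@H]2C(=O)N[C@@H](CCC2CC2)C(=O)C(=O)NC2CC2)C3(C)C)CCCCC1`, differs from compound 3 in one place: cyclopropyl in place of methyl on a saturated chain carbon, three bonds along the chain from an amide-type nitrogen and a carbonyl carbon. Put simply, a propyl chain becomes a 2-cyclopropylethyl chain.

For the measured compounds named here, only one measured step touches this part of the molecule: a 2.3-fold higher number from compound 2 to compound 3 (0.35 log units; beyond the scatter). That step put hydrogen in place of methyl on a saturated chain carbon, and it was modest but beyond the scatter. Compound 4 moves in the opposite sense, since it adds carbon to the chain instead of removing it. A modest fall in this assay is therefore expected, of about the size of that single step. Going by the values given here, no measured compound carries the new ring, so this reading is uncertain, and a change within the scatter remains possible.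

The estimated change is a 2.0-fold lower number from compound 3 to compound 4 (0.30 log units; within the scatter). For compound 4 the estimated value is 7500 ng.h/mL, with an expected range from 2800 ng.h/mL to 19000 ng.h/mL.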

Compound 4, area under the concentration-time curve: 2600 ng.h/mL
For compound 4 the middle estimate is 2.9-fold (0.46 log units) above the measured one, outside the stated range (below it).
By their numbers in this assay, from the lowest: compounds 1 and 4 (each within the scatter of the next); then compound 2; then compound 3.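

In this assay, this position tolerates a larger group poorly: exchanging the propyl chain for the 2-cyclopropylethyl chain gives a 5.7-fold lower number from compound 3 to compound 4 (0.76 log units; beyond the scatter), the largest step yet seen at this carbon. The ring-bearing chain also falls short of the butyl chain, with a 2.5-fold lower number from compound 2 to compound 4 (0.40 log units; beyond the scatter), so the three chains now order as propyl, then butyl, then 2-cyclopropylethyl, and the earlier step, a 2.3-fold higher number from compound 2 to compound 3 (0.35 log units; beyond the scatter), no longer stands alone as a sign that adding carbon here lowers exposure. Nothing at hand explains why the ring-bearing chain gives the lowest number of the three.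

From the compounds shown here alone, what remains open is whether the fall belongs to the cyclopropyl ring itself or simply to the greater reach of the chain, a question that a pentyl chain at this carbon could help to settle. Going by these compounds, it is also open whether a cyclopropylmethyl chain or an ethyl chain, each shorter than the 2-cyclopropylethyl chain, would bring the number back towards that of compound 3 or carry it higher still.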